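Compound 2 and an isopropyl swap at the assay limit

The source may hold more compounds than are shown below. What is called first, only, known or untested is meant among the compounds shown, and "the series" means these compounds.

In an ADME assay on L929 cells (Mus musculus) for cytotoxicity, with a stated time of 72 h (on this read-out higher numbers stand for weaker inhibition and lower numbers for stronger inhibition), compound 2 (`CC(=O)C(C)Oc1ccc2c(c1)B(O)OC2`) gives > 10 ug/mL as its result, and this is a limit and not a number. Compound 1 (`COC(=O)COc1ccc2c(c1)B(O)OC2`) gives > 10 ug/mL as a limit too. Compound 3 (`CC(=O)C(C)(C)Oc1ccc2c(c1)B(O)OC2`) gives > 10 ug/mL as a limit as well. Compound 2 therefore has no exact standing, and the series offers only the limit of > 10 ug/mL in this assay, at which 3 of the 3 values shown sit, as its common ground.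

The change to compound 4 (`CC(=O)C(Oc1ccc2c(c1)B(O)OC2)C(C)C`) is isopropyl in place of methyl on a saturated chain carbon bound to a carbonyl carbon and an oxygen on an aromatic ring and reads as isopropyl in place of methyl on a saturated chain carbon bound to a carbonyl carbon and an oxygen on an aromatic ring. The steps a step that the two limits leave unreadable from compound 1 to compound 2 and a step that the two limits leave unreadable from compound 2 to compound 3 bear on it, the second at the same chain carbon, and with neither size readable no step beyond the scatter is expected. The estimated step is a step that the limit leaves unreadable from compound 2 to compound 4 with no direction claimed. Compound 4 is estimated at 20 ug/mL in this assay as a working figure. Its expected range for compound 4 runs from 8 ug/mL to 60 ug/mL and a limit is expected again.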

Compound 4, half-maximal inhibitory concentration: > 10 ug/mL
Compound 4: a limit, no number; the forecaster's own chance of this, stated with the estimate: 75%; the middle value is on the limit's open side.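

Compound 4 gives > 10 ug/mL in this assay, a limit and not a number. Among the compounds shown here, with compound 2 also at a limit, no step from compound 2 to compound 4 can be read. The compounds shown leave open the exact value of any of them in this assay, and whether isopropyl in place of methyl changes it at all.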